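Methyl in place of difluoroethyl on the nitrogen-bound phenyl

A few compounds are considered here, and "the series" means these few. Any claim that something is new, unique, unknown or untested is made for them only; others in the source may bear on it.

Measured compounds in a functional assay on HOS cells (Homo sapiens) for inhibition, read by CCK-8 assay, with a stated time of 72 h, tested at 1 uM; on this read-out lower numbers stand for less inhibition and higher numbers for more inhibition at the one concentration tested (going by the name of the read-out):
compound 1 `COc1ccc(C)cc1N1C(=O)CSC1c1cccc(C(=O)NCCCCc2ccccc2)c1`: 42%
compound 2 `O=C(NCCCCc1ccccc1)c1cccc(C2SCC(=O)N2c2ccccc2)c1`: 55%
compound 3 `CC(F)(F)c1cccc(N2C(=O)CSC2c2cccc(C(=O)NCCCCc3ccccc3)c2)c1`: 23%

All three compounds share one core and differ only in the aromatic ring attached to the ring nitrogen. Compound 3 gives the lowest number of the three: compound 1 sits a number 19 percentage points lower from compound 1 to compound 3 (beyond the scatter), and compound 2 sits a number 32 percentage points lower from compound 2 to compound 3 (beyond the scatter). Both of these gaps lie beyond the usual scatter.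

Compound 4 `Cc1cccc(N2C(=O)CSC2c2cccc(C(=O)NCCCCc3ccccc3)c2)c1` has not yet been tested. Compared with compound 3 it changes in one place: methyl in place of 1,1-difluoroethyl on an aromatic carbon.

Two measured steps speak to this change. The step of a number 32 percentage points lower from compound 2 to compound 3 (beyond the scatter) shows that placing 1,1-difluoroethyl on an otherwise unsubstituted phenyl lowered the number by a large amount. The step of a number 19 percentage points lower from compound 1 to compound 3 (beyond the scatter) shows a modest fall when 1,1-difluoroethyl replaces a methoxy-and-methyl pattern. Methyl is a much smaller group than 1,1-difluoroethyl, so compound 4 is expected to land somewhere between compound 3 and compound 2 in this assay, with a step of a number 20 percentage points higher from compound 3 to compound 4 (beyond the scatter) upward and beyond the scatter.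

Compound 4 is therefore estimated at 43%, with a likely range from 25% to 60%.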

Compound 4, a percentage reported as inhibition, at one concentration (the size of the read-out at that concentration, not a potency): 84%
Estimate against measurement, compound 4: 41 percentage points below, outside the stated range (above it).
By their numbers in this assay, from the lowest: compound 3; then compound 1; then compound 2; then compound 4.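

In this assay, among the compounds shown here, the earlier compounds showed only falls when the plain phenyl of compound 2 gained substituents, but a methyl group on this aromatic carbon gives the opposite result, with a number 29 percentage points higher from compound 2 to compound 4 (beyond the scatter). The group at this one place therefore sets the direction of the change and not just its size: swapping 1,1-difluoroethyl for methyl gives a number 61 percentage points higher from compound 3 to compound 4 (beyond the scatter), a far larger move than the fall seen when 1,1-difluoroethyl replaced hydrogen. The methoxy group also matters in this series, since hydrogen in place of methoxy gives a number 42 percentage points higher from compound 1 to compound 4 (beyond the scatter), so the ring pattern of compound 1 cannot be read as a gain from its methyl group alone.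

For the compounds shown here, nothing measured on these compounds explains why such small changes in one group move the number so far. On these data alone, it also remains open how an ethyl group, a chlorine atom, a trifluoromethyl group or an amine at this same place would compare with methyl, and so whether methyl is a lone high point or part of a wider trend.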